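Weak cytotoxicity in a small series of pyrimidinedione analogs

The source may report more compounds than this note shows. Statements on the series, on what has been measured and on what is new or still open speak of the compounds shown alone.

Measured so far:
compound 1 `C=CCn1c(=O)/c(=C\c2cc(Br)ccc2F)[nH]c(=O)/c1=C\c1ccccc1OC` gives 34600 nM
compound 2 `C=CCn1c(=O)/c(=C\c2ccc(F)c(Br)c2)[nH]c(=O)/c1=C\c1ccccc1OC` gives "not active" (no number reported)
compound 3 `C=CCn1c(=O)/c(=C\c2ccc(C)cc2)[nH]c(=O)/c1=C\c1ccccc1OC` gives "not active" (no number reported)

All three compounds share one core and differ only in the aryl group on a double-bonded chain carbon. In a functional assay on HeLa cells (Homo sapiens) for cytotoxicity, read by CCK-8 assay, with a stated time of 72 h (on this read-out lower numbers stand for stronger inhibition and higher numbers for weaker inhibition), compound 1 gives 34600 nM, a weak effect. In this assay compound 2 gives "not active" (no number reported). Compound 3, carrying a 4-methylphenyl group, gives "not active" (no number reported) in this assay: no single number stands for it, and compound 2 is a further entry without a number. Compound 3 therefore sits at the inactive end of what has been measured, with only compound 1 showing a measurable, and still weak, value.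

Compound 4 `C=CCn1c(=O)/c(=C\c2cc(F)ccc2C)[nH]c(=O)/c1=C\c1ccccc1OC` has not yet been measured. It differs from compound 3 by 5-fluoro-2-methylphenyl in place of 4-methylphenyl on a double-bonded chain carbon bound to an aromatic carbon. Compound 1, which also carries two substituents on its aryl ring, gave a measurable value, so a small shift toward measurable but still weak inhibition is expected, though an outcome without a number remains likely. Compound 4 is estimated at 50000 nM, with a range from 20000 nM to 150000 nM.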

Compound 4, half-maximal inhibitory concentration: 2900 nM
The estimate for compound 4 lay 17-fold (1.24 log units) above the measured number; measured number outside the range, below it.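

In this assay, the aryl group on the double-bonded chain carbon bound to an aromatic carbon can shift the read-out well beyond the scatter: 5-fluoro-2-methylphenyl in place of 5-bromo-2-fluorophenyl gives a 12-fold lower number from compound 1 to compound 4 (1.08 log units; beyond the scatter). Compound 3, with 4-methylphenyl at this place, has no number, so the change to 5-fluoro-2-methylphenyl in compound 4 cannot be sized as a step, although it does turn an entry without a number into the value 2900 nM. No measurement shown here explains why this aryl group gives the lower number.

Going by these compounds, it remains open whether the methyl group or the fluorine of 5-fluoro-2-methylphenyl matters more, as neither is changed alone in these compounds. On these data alone, how an amine or a carboxylic acid on this aryl ring would behave also remains unknown.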